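A few compounds are considered here, and "the series" means these few. Any claim that something is new, unique, unknown or untested is made for them only; others in the source may bear on it.

The three measured compounds, all tested in a functional assay on MCF7 cells (Homo sapiens) for cytotoxicity; on this read-out lower numbers stand for stronger inhibition and higher numbers for weaker inhibition:

compound 1, `C=C/C=C\[C@H](C)[C@H](OC(N)=O)[C@@H](C)[C@H](O)[C@@H](C)C/C(C)=C\[C@H](C)[C@@H](O)[C@@H](C)/C=C\CCc1ccccc1`: 560 nM
compound 2, `C=C/C=C\[C@H](C)[C@H](OC(N)=O)[C@@H](C)[C@H](O)[C@@H](C)C/C(C)=C\[C@H](C)[C@@H](O)[C@@H](C)/C=C\CCc1ccc(Oc2ccccc2)cc1`: 10000 nM
compound 3, `C=C/C=C\[C@H](C)[C@H](OC(N)=O)[C@@H](C)[C@H](O)[C@@H](C)C/C(C)=C\[C@H](C)[C@@H](O)[C@@H](C)/C=C\CCc1ccc(C)c(F)c1`: 4000 nM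

All three share the same long chain and core and differ only in the aromatic ring at the chain end. Compound 3 stands second highest of the three numbers, with compound 2 giving a number an 18-fold higher number from compound 1 to compound 2 (1.25 log units; beyond the scatter) above compound 1, and compound 3 itself sitting a 7.1-fold higher number from compound 1 to compound 3 (0.85 log units; beyond the scatter). The step to compound 4, `C=C/C=C\[C@H](C)[C@H](OC(N)=O)[C@@H](C)[C@H](O)[C@@H](C)C/C(C)=C\[C@H](C)[C@@H](O)[C@@H](C)/C=C\CCc1cc(F)cc(F)c1`, changes that ring again: 3,5-difluorophenyl in place of 3-fluoro-4-methylphenyl on a saturated chain carbon, two bonds along the chain from a double-bonded chain carbon.

For the measured compounds named here, two measured steps bear on this. Adding a phenoxy to the ring gave an 18-fold higher number from compound 1 to compound 2 (1.25 log units; beyond the scatter), and swapping phenyl for 3-fluoro-4-methylphenyl gave a 7.1-fold higher number from compound 1 to compound 3 (0.85 log units; beyond the scatter); both additions to the ring weakened inhibition. Going by the values given here, no measured step compares two differently substituted rings with each other, so the move from compound 3 to compound 4 is not directly covered. Since both measured substituted rings stayed well above compound 1, compound 4 is expected to land near compound 3, with a step of a 1.1-fold lower number from compound 3 to compound 4 (0.06 log units; within the scatter) that may not exceed the scatter. Compound 4 is estimated at 3500 nM in this assay, within 1200 nM to 10000 nM.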

Compound 4, half-maximal inhibitory concentration: 2000 nM
The estimate for compound 4 lay 1.8-fold (0.24 log units) above the measured number, within the range that was stated.
By their numbers in this assay, from the lowest: compound 1; then compounds 4 and 3 (each within the scatter of the next); then compound 2.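

In this assay, replacing 3-fluoro-4-methylphenyl with 3,5-difluorophenyl gives a 2.0-fold lower number from compound 3 to compound 4 (0.30 log units; within the scatter) and so stays inside the usual noise: these two rings, which have the same count of heavy atoms, cannot be told apart on this read-out. Set against the plain phenyl ring, the new ring gives a 3.6-fold higher number from compound 1 to compound 4 (0.55 log units; beyond the scatter) and is a third substituted ring that weakens inhibition, so among the compounds shown, all three substituted rings at this chain end give higher numbers than compound 1, and none goes against this. No measurement at hand explains why substitution on this ring costs activity.

Going by these compounds, it remains open whether every substituent here weakens inhibition, or whether a ring carrying a single fluorine, an amine or a carboxylic acid could match or improve on the plain phenyl ring of compound 1. The length of the link to the ring is also untested among these compounds, so a longer chain in place of the two-carbon link of the 2-phenylethyl group remains an open question too.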